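The compounds below may be only part of what the source reports. "The series", "measured", "known", "first", "only" and "open" are said of these compounds alone.

Going by the values given here, in a functional assay on MCF7 cells (Homo sapiens) for cytotoxicity, read by sulforhodamine B assay, with a stated time of 48 h (on this read-out higher numbers stand for weaker inhibition and lower numbers for stronger inhibition), three compounds built on a shared core have numbers so far. Compound 1 (`N#Cc1c(-c2ccc(Cl)cc2)cc(-c2ccc(Cl)cc2)n([C@@H]2O[C@H](CO)[C@@H](O)[C@H]2O)c1=O`) gives 5.7 ug/mL, compound 2 (`N#Cc1c(-c2ccc(Cl)cc2)cc(-c2ccc(Cl)cc2)n(CC(O)CCl)c1=O`) gives 4.6 ug/mL, and compound 3 (`CC(=O)OC[C@H]1O[C@@H](n2c(-c3ccc(Cl)cc3)cc(-c3ccc(Cl)cc3)c(C#N)c2=O)[C@H](OC(C)=O)[C@@H](OC(C)=O)[C@@H]1OC(C)=O`) gives 6.3 ug/mL. Compound 1 is the middle of these three numbers and lies within the scatter of both others.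

The next compound is compound 4 (`N#Cc1c(-c2ccc(Cl)cc2)cc(-c2ccc(Cl)cc2)n([C@@H]2O[C@H](CO)[C@@H](O)[C@H](O)[C@H]2O)c1=O`), not yet measured. It carries 3,4,5-trihydroxy-6-(hydroxymethyl)oxan-2-yl in place of 3,4-dihydroxy-5-(hydroxymethyl)oxolan-2-yl on an aromatic nitrogen.

Among the compounds with values here, only one measured step bears directly on this change, as it replaces the same group at the same place. That step, a 1.2-fold lower number from compound 1 to compound 2 (0.09 log units; within the scatter), stays within the scatter. With so small a step, and with compound 3 at 6.3 ug/mL also close to compound 1, no shift beyond the scatter is expected in this assay, in either direction.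

The expected change is a 1.0-fold higher number from compound 1 to compound 4 (0.01 log units; within the scatter). For compound 4 the estimated value is 5.8 ug/mL, with an expected range of 3.2 ug/mL to 10.5 ug/mL.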

Compound 4, half-maximal inhibitory concentration: 14.2 ug/mL
For compound 4 the middle estimate is 2.4-fold (0.39 log units) below the measured one; the measured number lies above the stated range.
By their numbers in this assay, from the lowest: compounds 2, 1 and 3 (each within the scatter of the next); then compound 4.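

In this assay the group on the aromatic nitrogen proves not to be interchangeable: replacing 3,4-dihydroxy-5-(hydroxymethyl)oxolan-2-yl with 3,4,5-trihydroxy-6-(hydroxymethyl)oxan-2-yl gives a 2.5-fold higher number from compound 1 to compound 4 (0.40 log units; beyond the scatter) in a series whose earlier step stayed within the scatter. Replacing 3-chloro-2-hydroxypropyl with the same six-membered ring gives a 3.1-fold higher number from compound 2 to compound 4 (0.49 log units; beyond the scatter) and so sets compound 4 apart from both of these compounds, though only modestly. Nothing available accounts for this shift.

The ring size and the extra hydroxyl carbon change together between compound 1 and compound 4, so the compounds shown cannot separate the two. As far as these compounds go, it also remains open whether a simple aminoethyl chain or a carboxylic acid on that nitrogen would read like compound 2 or like compound 4.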